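Swapping an aryl amide cap on a shared flavonol core

The source may report more compounds than this note shows. Statements on the series, on what has been measured and on what is new or still open speak of the compounds shown alone.

Three compounds share one core and differ only in the aromatic group attached to the amide carbonyl. Compound 1 `Cc1ccc(C(=O)Nc2cccc(-c3oc4cc(-c5ccc(F)cc5)ccc4c(=O)c3O)c2)cc1` gives 2400 nM in a functional assay on MCF7 cells (Homo sapiens) for antiproliferative activity, read by CCK-8 assay, with a stated time of 72 h; a higher number here means a weaker inhibitor, a lower number a stronger inhibitor. Compound 2 `O=C(Nc1cccc(-c2oc3cc(-c4ccc(F)cc4)ccc3c(=O)c2O)c1)c1ccc(F)cc1F` gives 13500 nM, and compound 3 `Cc1cccc(C(=O)Nc2cccc(-c3oc4cc(-c5ccc(F)cc5)ccc4c(=O)c3O)c2)c1` gives 7850 nM. Among these, compound 3 stands second highest: the step of a 1.7-fold lower number from compound 2 to compound 3 (0.24 log units; within the scatter) is within the scatter, while the step of a 3.3-fold higher number from compound 1 to compound 3 (0.51 log units; beyond the scatter) lies beyond it, as does a 5.6-fold higher number from compound 1 to compound 2 (0.75 log units; beyond the scatter).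

Compound 4 `O=C(Nc1cccc(-c2oc3cc(-c4ccc(F)cc4)ccc3c(=O)c2O)c1)c1ccc(Cl)nc1` is not yet measured. It differs from compound 3 by 6-chloropyridin-3-yl in place of 3-methylphenyl on a carbonyl carbon. Among the measured compounds shown here, no measured step introduces a ring nitrogen or a chlorine on this cap, so the closest guides are the moves away from compound 1, both of which gave higher numbers, and the flat comparison between compound 2 and compound 3. On that basis the expected step for compound 4 is a 1.0-fold higher number from compound 3 to compound 4 (0.01 log units; within the scatter), essentially none beyond the scatter. The estimate for compound 4 in this assay is 8000 nM, with a range from 3000 nM to 22000 nM.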

Compound 4, half-maximal inhibitory concentration: 2890 nM
Estimate against measurement, compound 4: 2.8-fold (0.44 log units) above; measured number outside the range, below it.
By their numbers in this assay, from the lowest: compounds 1 and 4 (each within the scatter of the next); then compounds 3 and 2 (each within the scatter of the next).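

In this assay, the 6-chloropyridin-3-yl cap brings a ring nitrogen and a chlorine to the amide carbonyl, and it gives a 2.7-fold lower number from compound 3 to compound 4 (0.43 log units; beyond the scatter) and a 4.7-fold lower number from compound 2 to compound 4 (0.67 log units; beyond the scatter). With a 1.2-fold higher number from compound 1 to compound 4 (0.08 log units; within the scatter), the new cap cannot be told apart from the 4-methylphenyl cap, so a ring of carbon only is not required at this position for a number in the range of compound 1. Nothing measured here explains why this change lowers the number.

Whether the ring nitrogen or the chlorine accounts for the shift stays open, and a 4-chlorophenyl or an unsubstituted pyridin-3-yl cap would separate the two. Also open, going by these compounds, is how a cap carrying an amine or a carboxylic acid would behave in this assay.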